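Working notes: compound 2 to compound 3

This account rests on a few compounds, and the source may have more. Where it says the series, first, only, none or still open, it means among the compounds named here.

Compound 1 `O=C(C1CCOCC1)N1CC[C@](c2ccc(C(OCc3c(F)cccc3F)(C(F)(F)F)C(F)(F)F)cc2)(S(=O)(=O)c2ccc(F)cc2)C1` gives 29%
Compound 2 `O=C(O)[C@H]1CC[C@H](C(=O)N2CC[C@](c3ccc(C(OCc4ccccc4OC(F)(F)F)(C(F)(F)F)C(F)(F)F)cc3)(S(=O)(=O)c3ccc(F)cc3)C2)CC1` gives 81%

In an ADME assay on microsomes from liver (Mus musculus) for metabolic stability, with a stated time of 10 min (a lower number here means that less of the compound is left, a higher number that more of the compound is left), compound 2 stands at 81%, the higher of the two numbers, and the gap down to compound 1 lies beyond the scatter. Compound 3 `O=C(O)[C@H]1CC[C@H](C(=O)N2CC[C@](c3ccc(C(OCC4CCCCC4)(C(F)(F)F)C(F)(F)F)cc3)(S(=O)(=O)c3ccc(F)cc3)C2)CC1` has not yet been measured. Its difference from compound 2 is cyclohexyl in place of 2-(trifluoromethoxy)phenyl on a saturated chain carbon bound to an oxygen on a saturated carbon.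

Going by the values given here, the series holds no measured step for this change, and compounds 1 and 2 differ in more than one place. A fall in this assay is expected, though on thin evidence, because compound 2 at 81% leaves more room below than above. The expected size is a number 21 percentage points lower from compound 2 to compound 3 (beyond the scatter). Compound 3 is estimated at 60%, with an expected range of 35% to 85%.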

Compound 3, percent of the compound remaining: 78%
Beside the measured number, compound 3's estimate is 18 percentage points below it; low and high end bracket the measured number.
By their numbers in this assay, from the lowest: compound 1; then compounds 3 and 2 (each within the scatter of the next).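

In this assay, going by these compounds alone, the new pair gives the first single-place reading at this position: a number 3 percentage points lower from compound 2 to compound 3 (within the scatter). On this shared core, then, cyclohexyl and 2-(trifluoromethoxy)phenyl on a saturated chain carbon bound to an oxygen on a saturated carbon cannot be told apart in this read-out, so neither the aromatic ring nor the trifluoromethoxy group is required for a value at this level. Nothing measured here bears on why the two compounds stand level.

Still open, going by these compounds, is how an amine or a longer chain in place of cyclohexyl at this same place would read in this assay. Compound 2 and compound 3 each differ from compound 1 in more than one place, so the value of compound 1, 29%, cannot be assigned to any single change.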